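Swapping Methoxy for Ethyl on the Acyl Cap

A few compounds are considered here, and "the series" means these few. Any claim that something is new, unique, unknown or untested is made for them only; others in the source may bear on it.

In an ADME assay on a cell-free system (plasma, Homo sapiens) for metabolic stability, with a stated time of 90 min (on this read-out lower numbers stand for a less stable compound and higher numbers for a more stable compound), three compounds built on one shared core have been measured. Compound 1 `Cc1ncsc1-c1ccc(CNC(=O)[C@@H]2C[C@@H](O)CN2C(=O)[C@@H](NC(=O)CCCCCOC(=O)CC(c2ccccc2)c2ccccc2)C(C)(C)C)cc1` gives 58%. Compound 3 `CCCCOc1ccc(-c2ccc(C(=O)NCCCCCC(=O)N[C@H](C(=O)N3C[C@H](O)C[C@H]3C(=O)NCc3ccc(-c4scnc4C)cc3)C(C)(C)C)cc2)cc1` gives 83%. Compound 2 `COCC(=O)NCCCCCC(=O)N[C@H](C(=O)N1C[C@H](O)C[C@H]1C(=O)NCc1ccc(-c2scnc2C)cc1)C(C)(C)C` gives 126% and stands highest of the three: compound 3 is its nearest neighbour, lower by a margin beyond the scatter, and compound 1 is the furthest, lower again by a margin beyond the scatter.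

Compound 4 `CCCC(=O)NCCCCCC(=O)N[C@H](C(=O)N1C[C@H](O)C[C@H]1C(=O)NCc1ccc(-c2scnc2C)cc1)C(C)(C)C` has not yet been measured in this assay. It differs from compound 2 in one place (ethyl in place of methoxy on a saturated chain carbon bound to a carbonyl carbon). Within the data shown here, no pair among the measured compounds differs in a single place, so no measured step shows what this exchange does; the caps of compound 1 and compound 3 differ from that of compound 2 in many places at once, and their values say nothing about a methoxy against an ethyl on its own.

Compound 4 is therefore expected to stay close to compound 2, with the step of a number 14 percentage points lower from compound 2 to compound 4 (beyond the scatter) expected to fall within the scatter or only slightly below it. Compound 4 is estimated at 112% in this assay, with a range from 85% to 135%.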

Compound 4, percent of the compound remaining: 83%
Beside the measured number, compound 4's estimate is 29 percentage points above it, and the stated range ends above it.
By their numbers in this assay, from the lowest: compound 1; then compounds 3 and 4 (each within the scatter of the next); then compound 2.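

In this assay, the only single-place exchange shown on the acyl cap gives a number 43 percentage points lower from compound 2 to compound 4 (beyond the scatter), so this saturated chain carbon bound to a carbonyl carbon is not indifferent to the group it carries. Methoxy and ethyl have the same count of heavy atoms, and the exchange replaces one oxygen with one carbon and removes the one hydrogen-bond acceptor of methoxy; an exchange this small in atom count is enough to produce a large step beyond the scatter. No measurement at hand bears on why the read-out moves with this exchange.

Going by these compounds, it remains open whether a hydroxyl group or an amine on this carbon would give a value closer to that of compound 2 or of compound 4, and whether a longer chain such as butyl would differ from ethyl. One step also cannot show whether ethyl in place of methoxy would have an effect of similar size on a different cap or elsewhere on the shared core.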